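The compounds below may be only part of what the source reports. "The series", "measured", "known", "first", "only" and "open" are said of these compounds alone.

Measured compounds:
compound 1 `COC(=N)c1c(Cl)n(C2O[C@H](CO)[C@@H](O)[C@H]2O)c2cc(Cl)c(Cl)cc12` — in a functional assay on KB cells (Homo sapiens) for cytotoxicity, read by spectrophotometry and crystal violet staining (a lower number here means a stronger inhibitor, a higher number a weaker inhibitor), compound 1 gives 50000 nM
compound 2 `COC(=O)N/N=C/c1c(Cl)n(C2O[C@H](CO)[C@@H](O)[C@H]2O)c2cc(Cl)c(Cl)cc12` — compound 2 gives 20000 nM
compound 3 `NC(=O)N/N=C/c1c(Cl)n(C2O[C@H](CO)[C@@H](O)[C@H]2O)c2cc(Cl)c(Cl)cc12` — compound 3 gives > 100000 nM

On the numbers shown, compound 3 has only a limit of this assay and no number of its own, (the limit of > 100000 nM in this assay, at which 1 of the 3 values shown sits). The measured steps run a 2.5-fold lower number from compound 1 to compound 2 (0.40 log units; beyond the scatter), an at least 2.0-fold higher number from compound 1 to compound 3 (0.30 log units; that floor lies within the scatter) and an at least 5.0-fold higher number from compound 2 to compound 3 (0.69 log units; beyond the scatter). Compound 4 `CN(C)/N=C/c1c(Cl)n(C2O[C@H](CO)[C@@H](O)[C@H]2O)c2cc(Cl)c(Cl)cc12` is not yet measured; it differs from compound 3 by dimethylamino in place of ureido on a double-bonded nitrogen. For the measured compounds named here, no measured step exchanges the group on the double-bonded nitrogen in this way; the nearest is the exchange on the carbonyl carbon, an at least 5.0-fold higher number from compound 2 to compound 3 (0.69 log units; beyond the scatter). With little to build on, compound 4 is expected to land within the measured range, a step of an at least 2.0-fold lower number from compound 3 to compound 4 (0.30 log units; that floor lies within the scatter). The estimate for compound 4 in this assay is 50000 nM, between 10000 nM and 200000 nM.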

Compound 4, half-maximal inhibitory concentration: 70000 nM
Beside the measured number, compound 4's estimate is 1.4-fold (0.15 log units) below it; the range from low to high includes it.
By their numbers in this assay, from the lowest: compound 2; then compounds 1 and 4 (each within the scatter of the next). At a limit, above all of these: compound 3.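

In this assay, dimethylamino in place of (methoxycarbonyl)amino on the double-bonded nitrogen gives a 3.5-fold higher number from compound 2 to compound 4 (0.54 log units; beyond the scatter), so the group at this position can lose its carbonyl and still give a measurable value, though a weaker one than compound 2. In place of ureido the change gives an at least 1.4-fold lower number from compound 3 to compound 4 (0.15 log units; that floor lies within the scatter), and compound 3 stands only at a limit of the assay: the limit of > 100000 nM in this assay, at which 1 of the 4 values shown sits. The step of a 1.4-fold higher number from compound 1 to compound 4 (0.15 log units; within the scatter) sets no order between these two compounds.

Still open, going by these compounds, is how a free amino group or a morpholine ring on the double-bonded nitrogen would read in this assay. A longer alkyl chain on the amino nitrogen is equally unsettled.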